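The source may report more compounds than this note shows. Statements on the series, on what has been measured and on what is new or still open speak of the compounds shown alone.

Measured so far:
Compound 1 `CCN(CC)CCN(C)c1ccc(Cn2c(=O)[nH]c3c(N)nc(C(F)(F)F)cc32)cn1`: 24 mL.min-1.g-1
Compound 2 `CN(CCN1CCCCC1)c1ccc(Cn2c(=O)[nH]c3c(N)nc(C(F)(F)F)cc32)cn1`: 25 mL.min-1.g-1
Compound 3 `CN1CCN(CCN(C)c2ccc(Cn3c(=O)[nH]c4c(N)nc(C(F)(F)F)cc43)cn2)CC1`: 25 mL.min-1.g-1

In an in vitro ADME assay on microsomes from liver (Homo sapiens) for pharmacokinetics (a lower number here means slower removal, a higher number faster removal of the compound), the three numbers sit level: the steps of a 1.0-fold higher number from compound 1 to compound 2 (0.02 log units; within the scatter), a 1.0-fold higher number from compound 1 to compound 3 (0.02 log units; within the scatter) and no change at the digits printed from compound 2 to compound 3 (within the scatter) are all within the scatter, so compound 1 stands indistinguishable from compound 2 and compound 3. Compound 4 `CN(C)CCNc1ccc(Cn2c(=O)[nH]c3c(N)nc(C(F)(F)F)cc32)cn1` is the next step from compound 1, with (2-(dimethylamino)ethyl)amino in place of (2-(diethylamino)ethyl)(methyl)amino on an aromatic carbon. Every measured step exchanged only the amine at the end of the saturated chain and moved nothing beyond the scatter; none of them removed the methyl from the ring-bound nitrogen or shortened the chain-end amine, so the bearing of those steps on compound 4 is indirect. The step from compound 1 to compound 4 is therefore expected to be a 1.1-fold lower number from compound 1 to compound 4 (0.04 log units; within the scatter), within the scatter. Compound 4 is estimated at 22 mL.min-1.g-1, between 10 mL.min-1.g-1 and 45 mL.min-1.g-1.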

Compound 4, intrinsic clearance in microsomes in the Homo sapiens assay: 9 mL.min-1.g-1
For compound 4 the middle estimate is 2.4-fold (0.39 log units) above the measured one; measured number outside the range, below it.
By their numbers in the Homo sapiens assay, from the lowest: compound 4; then compounds 1, 2 and 3 (each within the scatter of the next).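

In the Homo sapiens assay the exchange on this aromatic carbon moved the number where swaps of the chain-end amine had not: a 2.7-fold lower number from compound 1 to compound 4 (0.43 log units; beyond the scatter) and a 2.8-fold lower number from compound 2 to compound 4 (0.44 log units; beyond the scatter) and a 2.8-fold lower number from compound 3 to compound 4 (0.44 log units; beyond the scatter) all lie beyond the scatter. In a physicochemical assay for lipophilicity (on this read-out higher numbers stand for higher lipophilicity and lower numbers for lower lipophilicity), compound 1 gives 1.3 and compound 4 gives 0.7 on that scale. For this pair, the lower number of compound 4 thus travels with lower lipophilicity: the measured distribution coefficient of compound 1, 1.3, and of compound 4, 0.7, a number 0.60 log units lower (beyond the scatter).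

The step removes the methyl from the nitrogen and brings in the dimethylamino end together, so the compounds shown do not separate the two. Going by these compounds, whether a morpholine at the chain end or a longer chain would follow compound 4 also stays open.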